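Sulfonamide imide series: N-substituent variation at the imide

This account rests on a few compounds, and the source may have more. Where it says the series, first, only, none or still open, it means among the compounds named here.

Measured so far in an assay on isolated protein for inhibition of lactase/phlorizin hydrolase (Rattus norvegicus), read by colorimetric assay; on this read-out lower numbers stand for stronger inhibition and higher numbers for weaker inhibition:
compound 1 `Cc1ccc(S(=O)(=O)Nc2ccc3c(c2)C(=O)N(C)C3=O)cc1` gives > 200000 nM.
compound 2 `Cc1ccc(S(=O)(=O)Nc2ccc3c(c2)C(=O)N(Cc2ccccc2)C3=O)cc1` gives > 200000 nM.

For compound 1 the value in this assay is only a limit of the assay, not a number. For compound 2 the value is likewise a limit. Both values sit at the same limit (the limit of > 200000 nM in this assay, at which 2 of the 2 values shown sit), so the step that the two limits leave unreadable from compound 1 to compound 2 cannot be read. Compound 3 `Cc1ccc(S(=O)(=O)Nc2ccc3c(c2)C(=O)N(CCOc2ccc(O)cc2)C3=O)cc1` differs from compound 1 by (4-hydroxyphenoxy)methyl in place of hydrogen on a saturated chain carbon bound to an amide-type nitrogen in a ring. Among the measured compounds shown here, the only step that bears on it, that from compound 1 to compound 2, is unreadable, so no direction beyond the scatter can be drawn from it. Compound 3 is expected to give about 250000 nM (range 60000 nM to 1000000 nM), which means an expected step that the limit leaves unreadable from compound 1 to compound 3.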

Compound 3, half-maximal inhibitory concentration: 100000 nM
The estimate for compound 3 lay 2.5-fold (0.40 log units) above the measured number, and the stated range covers the measured number.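

Compound 3 is the only compound shown with a number in this assay, so (4-hydroxyphenoxy)methyl on this saturated chain carbon gives a readable value. The series shows an at least 2.0-fold lower number from compound 1 to compound 3 (0.30 log units; that floor lies within the scatter) and an at least 2.0-fold lower number from compound 2 to compound 3 (0.30 log units; that floor lies within the scatter), so neither step is established beyond the scatter. Compound 1 and compound 2 remain at a limit, not a number: the limit of > 200000 nM in this assay, at which 2 of the 3 values shown sit.

As far as these compounds go, the full size of both steps stays open, as does the part played by the hydroxy group on the aromatic ring. Also open, from the compounds shown here alone, is whether an amine or a carboxylic acid on this chain would give a lower number.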